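The compounds below may be only part of what the source reports. "The series", "measured", "known", "first", "only" and "open" are said of these compounds alone.

Compound 1 `CC(C)=CC[C@@H](OC[C@H](C)O)C1=CC(=O)c2c(O)ccc(O)c2C1=O` is the starting point of this account. In a functional assay on DU-145 cells (Homo sapiens) for cytotoxicity, read by MTT assay (a lower number here means a stronger inhibitor, a higher number a weaker inhibitor), compound 1 gives 24500 nM. Two close relatives have been measured alongside it. Compound 2 `CC(C)=CC[C@@H](OCC(C)O)C1=CC(=O)c2c(O)ccc(O)c2C1=O` gives 16100 nM in this assay, and compound 3 `CC(=O)OC(C)CO[C@H](CC=C(C)C)C1=CC(=O)c2c(O)ccc(O)c2C1=O` gives 16600 nM. Going by the values given here, neither departs from compound 1 beyond the scatter: the step of a 1.5-fold lower number from compound 1 to compound 2 (0.18 log units; within the scatter) and the step of a 1.5-fold lower number from compound 1 to compound 3 (0.17 log units; within the scatter) are both small, and the only thing separating compounds 1 and 2 is the fact that one of compounds 1 and 2 is drawn with a defined configuration and the other without, at the place where they differ. The step of a 1.0-fold higher number from compound 2 to compound 3 (0.01 log units; within the scatter) is likewise negligible, so exchanging the acetyl for hydrogen on the side-chain oxygen leaves the number where it was.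

Compound 4 `CCCC(C)(O)CC(=O)O[C@H](CC=C(C)C)C1=CC(=O)c2c(O)ccc(O)c2C1=O` is not yet measured. It differs from compound 1 by (2-hydroxy-2-methylpentyl)carbonyl in place of 2-hydroxypropyl on an oxygen on a saturated carbon. The measured steps all concern this same side chain on the shared core, and none of them moved the number beyond the scatter, so a larger ester in place of the hydroxypropyl ether is expected to stay in the same range. Compound 4 is therefore estimated at 18000 nM in this assay, between 7000 nM and 45000 nM, which would mean a step of a 1.4-fold lower number from compound 1 to compound 4 (0.13 log units; within the scatter), not expected to exceed the scatter.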

Compound 4, half-maximal inhibitory concentration: 75000 nM
Compound 4: the middle estimate sits 4.2-fold (0.62 log units) below what was measured, and the stated range ends below it.
By their numbers in this assay, from the lowest: compounds 2, 3 and 1 (each within the scatter of the next); then compound 4.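

In this assay, going by these compounds alone, the oxygen on a saturated carbon turns out to be a place where the number can move: (2-hydroxy-2-methylpentyl)carbonyl in place of 2-hydroxypropyl gives a 3.1-fold higher number from compound 1 to compound 4 (0.49 log units; beyond the scatter), the first change to pass the scatter, and it goes towards a weaker inhibitor. The other two comparisons point the same way, with a 4.5-fold higher number from compound 3 to compound 4 (0.65 log units; beyond the scatter) and a 4.7-fold higher number from compound 2 to compound 4 (0.67 log units; beyond the scatter), so compound 4 stands apart from compounds 1, 2 and 3, which remain within the scatter of one another and show that not every change to this side chain leaves the number in place. Nothing in the available evidence bears on why this exchange raises the number.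

The exchange alters the link to the oxygen, the length of the chain and the branching at the hydroxyl-bearing carbon all at once, and the compounds shown cannot say which of these carries the step. On these data alone, it also remains open whether a simple propanoyl group on this oxygen would behave like compound 4, and whether an amine or a carboxylic acid on the chain would move the number in either direction.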